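A few compounds are considered here, and "the series" means these few. Any claim that something is new, unique, unknown or untested is made for them only; others in the source may bear on it.

Measured in an ADME assay on NIH3T3 cells (Mus musculus) for cytotoxicity, read by MTT assay, with a stated time of 24 h; a higher number here means a weaker inhibitor, a lower number a stronger inhibitor:
- Compound 1 `Cc1nnc(SCC(=O)N/N=c2/scc(-c3ccc([N+](=O)[O-])cc3)n2-c2ccccc2)s1`: 177 ug/mL
- Compound 2 `N#Cc1ccc(-c2cs/c(=N/NC(=O)CSc3ncccn3)n2-c2ccccc2)cc1`: < 3.9 ug/mL

Compound 2 is known only as a limit, < 3.9 ug/mL. Compound 3 `O=C(CSc1ncccn1)N/N=c1/scc(-c2ccc([N+](=O)[O-])cc2)n1-c1ccccc1` keeps the rest of compound 2 and changes one group: nitro in place of cyano on an aromatic carbon, para to a large group. Going by the values given here, no measured pair isolates 4-cyanophenyl to 4-nitrophenyl. Compound 1 also carries 4-nitrophenyl and gives 177 ug/mL in this assay, but it differs from compound 3 at its other end as well, so only a moderate move toward weaker inhibition is expected. The estimated change is an at least 3.0-fold higher number from compound 2 to compound 3 (0.48 log units; beyond the scatter), and a result reported only as a limit remains possible. Compound 3 is estimated at 12 ug/mL, with an expected range of 3 ug/mL to 80 ug/mL.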

Compound 3, half-maximal inhibitory concentration: 193 ug/mL
Compound 3: the middle estimate sits 16-fold (1.21 log units) below what was measured, outside the stated range (above it).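

In this assay this position is sensitive: nitro in place of cyano on an aromatic carbon, para to a large group, gives an at least 49-fold higher number from compound 2 to compound 3 (1.69 log units; beyond the scatter). With 4-nitrophenyl held constant, the change at the other end, pyrimidin-2-yl in place of 5-methyl-1,3,4-thiadiazol-2-yl on a sulfur, gives a 1.1-fold higher number from compound 1 to compound 3 (0.04 log units; within the scatter), so that exchange leaves the read-out within the scatter. Compound 2 is a limit and not a number, so the step to compound 3 gives only a lower bound: the limit of < 3.9 ug/mL in this assay, at which 1 of the 3 values shown sits.

As far as these compounds go, whether an amine, a carboxylic acid or a methoxy group at this same place would read closer to 4-cyanophenyl or to 4-nitrophenyl remains open. Also open, from the compounds shown here alone, is whether 5-methyl-1,3,4-thiadiazol-2-yl and pyrimidin-2-yl read alike with 4-cyanophenyl in place.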